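Stability notes on the free ring-nitrogen analogue, compound 3

The source may hold more compounds than are shown below. What is called first, only, known or untested is meant among the compounds shown, and "the series" means these compounds.

Measured compounds:
- compound 1, `CCOC(=O)C1=C(S[C@@H]2CN[C@H](C(=O)Nc3cccc(C(=O)OCC)c3)C2)[C@H](C)[C@@H]2[C@@H]([C@@H](C)OC(=O)[C@@H](N)C(C)C)C(=O)N12`, in a physicochemical assay for metabolic stability, read by LC-MS, in phosphate buffer, with a stated time of 3 h, at pH 7.4, tested at 50 uM; on this read-out lower numbers stand for a less stable compound and higher numbers for a more stable compound: > 95%
- compound 2, `CCOC(=O)C1=C(S[C@H]2C[C@@H](C(=O)Nc3cccc(C(=O)OCC)c3)N(C(=O)OCc3oc(=O)oc3C)C2)[C@H](C)[C@@H]2[C@@H]([C@@H](C)O)C(=O)N12`, in this assay: > 95%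

Compound 2 stands at the upper limit of this assay; its value of > 95% is a limit, not a number. Compound 1 also sits at a limit. Both values shown in this series are limits, as summed up in the limit of > 95% in this assay, at which 2 of the 2 values shown sit, so no difference between compound 1 and compound 2 can be read from them.

Compound 3, `CCOC(=O)C1=C(S[C@@H]2CN[C@H](C(=O)Nc3cccc(C(=O)OCC)c3)C2)[C@H](C)[C@@H]2[C@@H]([C@@H](C)O)C(=O)N12`, is the next member. It differs from compound 2 by a hydrogen atom in place of a group of 11 heavy atoms (6 carbon, 5 oxygen; one five-membered aromatic ring with 2 hetero atoms), on an amine nitrogen in a ring; in words, a hydrogen atom in place of a group of 11 heavy atoms (6 carbon, 5 oxygen; one five-membered aromatic ring with 2 hetero atoms), on an amine nitrogen in a ring. Going by the values given here, no measured step exists for comparison. Given that compound 1, which also carries a hydrogen on that ring nitrogen, reaches > 95%, the step from compound 2 to compound 3 is expected to be none beyond the scatter, with a step that the limit leaves unreadable from compound 2 to compound 3. Compound 3 is therefore estimated at 96%, within 88% to 100%, most likely again reported as a limit.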

Compound 3, percent of the compound remaining: > 95%
Compound 3 ended at the assay's limit (the forecaster's own chance of this, stated with the estimate: 80%); the middle value is on the limit's open side.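

No step can be read between compound 1, compound 2 and compound 3 in this assay: the limit of > 95% in this assay, at which 3 of the 3 values shown sit.

The compounds shown leave open whether exchanging hydrogen for the group of 11 heavy atoms or for (1-amino-2-methylpropyl)carbonyl changes the percent remaining at all, and whether the three compounds differ in this assay.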